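Swapping formyl for vinyl in a cell toxicity test

The compounds below may be only part of what the source reports. "The series", "measured", "known", "first", "only" and "open" are said of these compounds alone.

Measured in a toxicity assay (RAW264.7 cells) for cytotoxicity, with Mus musculus as the target, read by MTT assay, with a stated time of 48 h; on this read-out higher numbers stand for lower toxicity in this test and lower numbers for higher toxicity in this test:
- compound 1 `C/C(C=O)=C\C[C@H]1[C@](C)(O)[C@@H](O)C[C@H]2C(C)(C)CCC[C@@]21C`: > 100000 nM (a limit, not a number)
- compound 2 `CC1=CC(=O)O[C@]12C[C@@H]1[C@@]3(C)CCCC(C)(C)[C@@H]3C[C@H](O)[C@@]1(C)O2`: > 100000 nM (a limit, not a number)

On these numbers, compound 1 stands at the limit of > 100000 nM in this assay, at which 2 of the 2 values shown sit, so only a limit is known for it, with no exact value. Compound 3 `C=C/C(C)=C/C[C@H]1[C@](C)(O)[C@@H](O)C[C@H]2C(C)(C)CCC[C@@]21C` has not yet been measured. It differs from compound 1 in one place: vinyl in place of formyl on a double-bonded chain carbon bound to a double-bonded chain carbon and a saturated chain carbon. Among the measured compounds shown here, no pair of measured compounds shows what this swap does. In this assay, no step beyond the usual scatter is expected, in either direction. The expected outcome is a number no higher from compound 1 to compound 3 (the limit leaves the size open). For compound 3 the estimate is 100000 nM, with an expected range from 30000 nM to 200000 nM.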

Compound 3, half-maximal cytotoxic concentration: 94500 nM
The estimate for compound 3 lay 1.1-fold (0.02 log units) above the measured number; measured number inside the range.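

With vinyl in place of formyl on a double-bonded chain carbon bound to a double-bonded chain carbon and a saturated chain carbon, this assay gives an exact number for compound 3, 94500 nM, so this position can carry a compound with a readable value. The swap reads as an at least 1.0-fold lower number from compound 1 to compound 3 (0.02 log units; that floor lies within the scatter), which means that only a floor for the step is known, and it does not establish a change. Compound 1 has only a limit, not a number, so the full size of the step stays unknown: the limit of > 100000 nM in this assay, at which 2 of the 3 values shown sit.

On these data alone, what a carboxylic acid or an amine at this place would do in this assay remains open. So does whether a longer chain there would give a lower number, beyond the scatter, than compound 3.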